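Thienopyran carboxamide potentiators: hydroxyphenyl to pyrazole

The source may report more compounds than this note shows. Statements on the series, on what has been measured and on what is new or still open speak of the compounds shown alone.

Measured compounds:
compound 1 `CC1Cc2c(sc(NC(=O)c3ccccc3O)c2C(N)=O)C(C)O1` gives 236 nM
compound 2 `CC1(C)Cc2c(sc(NC(=O)c3ccccc3O)c2C(N)=O)C(C)(C)O1` gives 162 nM

Of the compounds shown here, two have been measured in an assay on cells for positive allosteric modulation of Cystic fibrosis transmembrane conductance regulator variant G551D (Homo sapiens), with stated times of 10 min and 2 min, in the presence of a further agent that is not named here; on this read-out higher numbers stand for an effect only at larger amounts of compound and lower numbers for an effect already at smaller amounts. Compound 1 `CC1Cc2c(sc(NC(=O)c3ccccc3O)c2C(N)=O)C(C)O1` gives 236 nM in this assay, and compound 2 `CC1(C)Cc2c(sc(NC(=O)c3ccccc3O)c2C(N)=O)C(C)(C)O1` gives 162 nM. The gap between the two numbers lies within the usual scatter of repeated measurements, so on these data compound 2 cannot be told apart from compound 1; the two stand together.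

Compound 3 `CC1(C)Cc2c(sc(NC(=O)c3ccn[nH]3)c2C(N)=O)C(C)(C)O1` has not yet been measured. It differs from compound 2 in one place: 1H-pyrazol-5-yl in place of 2-hydroxyphenyl on a carbonyl carbon. For the measured compounds named here, no step of this kind has been measured within this set, so there is nothing to say what such an exchange does to the read-out in this assay. The two measured compounds only show that changes to the shared core leave the number within scatter.

Given that absence, the estimate for compound 3 rests on compound 2 alone and carries a wide range. The expected step of a 2.8-fold higher number from compound 2 to compound 3 (0.44 log units; beyond the scatter) is a moderate loss, though none beyond the scatter would also be unsurprising. Compound 3 is therefore expected to give about 450 nM, between 100 nM and 2500 nM.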

Compound 3, half-maximal effective concentration: 339 nM
Beside the measured number, compound 3's estimate is 1.3-fold (0.12 log units) above it; measured number inside the range.
By their numbers in this assay, from the lowest: compounds 2, 1 and 3 (each within the scatter of the next, the first and the last beyond it).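

In this assay, replacing 2-hydroxyphenyl with 1H-pyrazol-5-yl on a carbonyl carbon whose other neighbour is an amide-type nitrogen gives a 2.1-fold higher number from compound 2 to compound 3 (0.32 log units; beyond the scatter), a modest change and the first in this set to touch this position rather than the shared core. The position therefore accepts a five-membered aromatic ring with 2 hetero atoms in place of a six-membered aromatic ring of carbon only, with a smaller group of the same hydrogen-bond donor and acceptor count, at a limited cost: compound 3 still gives 339 nM in this series. The data offer nothing that explains why the number moves with this exchange.

The compounds shown leave open how other groups on this carbonyl carbon would read, such as unsubstituted phenyl, imidazolyl or an N-methylpyrazole, and so whether the hydroxyl of the 2-hydroxyphenyl group or the ring itself accounts for the difference. Going by these compounds, the exchange is also seen on the core of compound 2 alone, so its size on the core of compound 1 remains unknown.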